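Biaryl substituent pattern and serotonin receptor 7 binding

The compounds below may be only part of what the source reports. "The series", "measured", "known", "first", "only" and "open" are said of these compounds alone.

The series shares one core: compound 1 `COc1ccccc1N1CCN(CCCCC(=O)NCc2ccccc2-c2ccc(Cl)cc2)CC1`, compound 2 `COc1ccccc1N1CCN(CCCCC(=O)NCc2ccccc2-c2c(OC)cccc2OC)CC1` and compound 3 `COc1ccccc1N1CCN(CCCCC(=O)NCc2ccccc2-c2cccc(Cl)c2)CC1` differ only in the aryl group attached to the benzylic ring. In an assay on CHO-K1 cells for displacement of a labelled ligand from 5-hydroxytryptamine receptor 7 (Homo sapiens), read by scintillation counting (a higher number here means a weaker inhibitor, a lower number a stronger inhibitor), compound 1 gives 25.9 nM and compound 2 gives 32.4 nM; the step of a 1.3-fold higher number from compound 1 to compound 2 (0.10 log units; within the scatter) lies within the scatter. Compound 3 gives 405 nM in this assay, the highest number of the three: the steps of a 16-fold higher number from compound 1 to compound 3 (1.19 log units; beyond the scatter) and a 13-fold higher number from compound 2 to compound 3 (1.10 log units; beyond the scatter) are both large and beyond the scatter.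

Compound 4 `COc1ccccc1N1CCN(CCCCC(=O)NCc2ccccc2-c2ccccc2F)CC1` is the next member, not yet measured. It differs from compound 3 by 2-fluorophenyl in place of 3-chlorophenyl on an aromatic carbon. The two measured steps into compound 3 bear on this change: a 4-chlorophenyl or a 2,6-dimethoxyphenyl each gave a much lower number than the 3-chlorophenyl, so moving away from the 3-chlorophenyl is expected to recover much of that loss. The 2-fluorophenyl is closer in its substitution pattern to the 2,6-dimethoxyphenyl of compound 2 than to the 3-chlorophenyl of compound 3, and a step toward the numbers of compound 1 and compound 2 is therefore expected in this assay.

Compound 4 is thus estimated at 50 nM, in a range from 15 nM to 200 nM, which means an expected step of an 8.1-fold lower number from compound 3 to compound 4 (0.91 log units; beyond the scatter).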

Compound 4, inhibition constant: 36.5 nM
Compound 4: middle estimate off by 1.4-fold (0.14 log units), on the high side; measured number inside the range.
By their numbers in this assay, from the lowest: compounds 1, 2 and 4 (each within the scatter of the next); then compound 3.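

In this assay, the step of an 11-fold lower number from compound 3 to compound 4 (1.05 log units; beyond the scatter) shows that the loss seen with the 3-chlorophenyl does not extend to every aryl group carrying a single halogen at this place: the 2-fluorophenyl, which sits ortho to a large group, matches the 3-chlorophenyl in heavy-atom count and in its lack of hydrogen-bond donors and acceptors, yet falls with the low-number compounds. The steps of a 1.1-fold higher number from compound 2 to compound 4 (0.05 log units; within the scatter) and a 1.4-fold higher number from compound 1 to compound 4 (0.15 log units; within the scatter) place the 2-fluorophenyl level with the 2,6-dimethoxyphenyl and the 4-chlorophenyl, so three differently substituted aryl groups now lie within the scatter of one another and compound 3 alone stands apart. No accompanying evidence bears on what separates the 3-chlorophenyl from the other three groups.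

The compounds shown leave open whether the weak binding of compound 3 belongs to chlorine specifically or to any substituent at that ring position, a question that a 3-fluorophenyl or a 3-methoxyphenyl would address. Also open, as far as these compounds go, is how an unsubstituted phenyl or a 2-chlorophenyl would compare with compound 4.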